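Amide substituent changes on a quinolone cytotoxicity series

A few compounds are considered here, and "the series" means these few. Any claim that something is new, unique, unknown or untested is made for them only; others in the source may bear on it.

Three compounds sharing one core carry a carbamoyl side chain that is varied at the amide-type nitrogen. Compound 1 `C#CCn1cc(C(=O)NC(CC(=O)Nc2ccccn2)c2ccccc2)c(=O)c2ccc(Cl)nc21` gives 5200 nM in a functional assay on KB cells (Homo sapiens) for cytotoxicity, read by MTT assay, with a stated time of 72 h; on this read-out higher numbers stand for weaker inhibition and lower numbers for stronger inhibition. Compound 3 `C#CCn1cc(C(=O)NC(CC(=O)Nc2ccccc2)c2ccccc2)c(=O)c2ccc(Cl)nc21` sits at a limit of this assay, > 10000 nM. Compound 2 `C#CCn1cc(C(=O)NC(CC(=O)NC2CCCCC2)c2ccccc2)c(=O)c2cc(F)c(Cl)nc21` also sits at a limit of this assay, > 10000 nM, so for compound 2 only a floor on the number is known, not a value. Among the measured compounds shown here, the one measured step, an at least 1.9-fold higher number from compound 1 to compound 3 (0.28 log units; that floor lies within the scatter), shows no clear movement; the limit of > 10000 nM in this assay, at which 2 of the 3 values shown sit, is where two of the three results end.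

Compound 4 `C#CCn1cc(C(=O)NC(CC(=O)NC2CCCC2)c2ccccc2)c(=O)c2cc(F)c(Cl)nc21` differs from compound 2 by cyclopentyl in place of cyclohexyl on an amide-type nitrogen. For the measured compounds named here, no measured step covers a change between two non-aromatic rings on the amide-type nitrogen, so the only guide is that compound 2 itself is at the limit. The step from compound 1 to compound 3 concerns aromatic groups and does not transfer. The most likely outcome is that compound 4 again reports only a limit in this assay; a number, if one appears, is expected to lie close to the limit. The expected step that the limit leaves unreadable from compound 2 to compound 4 is therefore set near zero. The estimate for compound 4 is 15000 nM, with a range from 5000 nM to 50000 nM.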

Compound 4, half-maximal inhibitory concentration: 4900 nM
Beside the measured number, compound 4's estimate is 3.1-fold (0.49 log units) above it, and the stated range ends above it.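

In this assay, cyclopentyl in place of cyclohexyl on the amide-type nitrogen gives an at least 2.0-fold lower number from compound 2 to compound 4 (0.30 log units; that floor lies within the scatter), and compound 4 is the only compound shown that pairs a non-aromatic ring at this nitrogen with a number rather than a limit. As far as these compounds go, compound 2 carries only a limit, > 10000 nM, so the true size of this step is unknown; it may exceed its floor, but that floor alone shows no clear movement. Among the compounds shown, a number at this nitrogen is no longer confined to the pyridin-2-yl of compound 1, while the phenyl of compound 3 and the cyclohexyl of compound 2 still end at the limit: the limit of > 10000 nM in this assay, at which 2 of the 4 values shown sit.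

Ring size at this nitrogen is covered only by cyclohexyl and cyclopentyl, so it remains open whether cyclobutyl, cycloheptyl, an open chain such as n-pentyl or an amine-bearing ring such as piperidin-4-yl would give a number in this assay. Also open, from the compounds shown here alone, is whether cyclopentyl on the core of compound 1 would read as it does on the core of compound 4.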